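The source may hold more compounds than are shown below. What is called first, only, known or untested is meant among the compounds shown, and "the series" means these compounds.

Three compounds share one core and differ only in the group sitting on a single aromatic carbon of a fused ring system. Compound 1 `CC#C[C@@H](CC(=O)O)c1ccc(OC[C@H]2COc3ccc(Cl)cc3O2)cc1` carries a chloro there, and in a functional assay on HEK293 cells for agonist activity at Free fatty acid receptor 1 (Homo sapiens), read by fluorescence and calcium flux, with a stated time of 10 min (a higher number here means a larger maximal response, a lower number a smaller maximal response), compound 1 reaches 86%. Compound 2 `CC#C[C@@H](CC(=O)O)c1ccc(OC[C@H]2COc3ccccc3O2)cc1` has hydrogen in that place; in this assay compound 2 gives 70%. Compound 3 `CC#C[C@@H](CC(=O)O)c1ccc(OC[C@H]2COc3ccc(OC(F)(F)F)cc3O2)cc1` bears a trifluoromethoxy, and in this assay compound 3 gives 73%. Among these three numbers compound 3 stands second highest: its nearest neighbour is compound 2, within the scatter, while the gap to compound 1 lies beyond it.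

Compound 4 `CC#C[C@@H](CC(=O)O)c1ccc(OC[C@H]2COc3ccc(C(C)=O)cc3O2)cc1` differs from compound 3 in one place: acetyl in place of trifluoromethoxy on an aromatic carbon. All three measured steps concern exchanges of the group on this same aromatic carbon. a number 16 percentage points lower from compound 1 to compound 2 (beyond the scatter) and a number 13 percentage points lower from compound 1 to compound 3 (beyond the scatter) were modest, whereas a number 3 percentage points higher from compound 2 to compound 3 (within the scatter) stayed within the scatter. Exchanging groups at this carbon has so far shifted the maximal response only modestly, and an acetyl has not been measured on any compound, so the expected step is small. The expected step is a number 1 percentage points lower from compound 3 to compound 4 (within the scatter), with no change beyond the scatter anticipated. Compound 4 is therefore estimated at 72%, with a range from 58% to 86%.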

Compound 4, largest response reached (Emax), in percent of the reference or control that the assay uses: 51%
For compound 4 the middle estimate is 21 percentage points above the measured one; measured number outside the range, below it.
By their numbers in this assay, from the lowest: compound 4; then compounds 2 and 3 (each within the scatter of the next); then compound 1.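

In this assay acetyl in place of hydrogen gives a number 19 percentage points lower from compound 2 to compound 4 (beyond the scatter) and so shows that a group on this aromatic carbon can also pull the maximal response under that of the compound with hydrogen there, whereas until now only chloro stood apart, on the upper side. Acetyl in place of trifluoromethoxy gives a number 22 percentage points lower from compound 3 to compound 4 (beyond the scatter) even though the two groups count alike in hydrogen-bond donors, hydrogen-bond acceptors, net charge and absence of a ring, so those counts do not separate them; the counted differences are the number of heavy atoms and the double bond that acetyl brings. With a number 35 percentage points lower from compound 1 to compound 4 (beyond the scatter) as the first large step among these compounds, this single carbon now spans a wide range of maximal response, but nothing available explains the fall.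

The compounds shown leave open whether the low response belongs to the carbonyl of the acetyl or to the acetyl as a whole, which a methyl ester, an amide or an ethyl group on the same carbon could help to separate. They also leave open whether a fluoro, bromo or methyl group would match the response of chloro.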